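4-Chlorophenyl to 4-methylphenyl: working notes on the series

This account rests on a few compounds, and the source may have more. Where it says the series, first, only, none or still open, it means among the compounds named here.

In a functional assay on A549 cells (Homo sapiens) for cytotoxicity, read by sulforhodamine B assay (on this read-out lower numbers stand for stronger inhibition and higher numbers for weaker inhibition), compound 1 (`Cc1ccc(-c2cc3cc(C)ccc3c(O)n2)cc1`) gives 5620 nM while compound 2 (`COc1ccc(-c2cc3cc(C)ccc3c(N3CCN(C)CC3)n2)cc1`) gives 7410 nM and compound 3 (`Cc1ccc2c(N3CCN(C)CC3)nc(-c3ccc(Cl)cc3)cc2c1`) stands at 3190 nM on this read-out. Compound 3 lies within the scatter of compound 1 and beyond the scatter under compound 2. Compound 4 (`Cc1ccc(-c2cc3cc(C)ccc3c(N3CCN(C)CC3)n2)cc1`) carries methyl in place of chloro on an aromatic carbon, para to a large group (methyl in place of chloro on an aromatic carbon). For the measured compounds named here, the only measured step at that place is modest, a 2.3-fold lower number from compound 2 to compound 3 (0.37 log units; beyond the scatter) with chloro in place of methoxy, and no step involving methyl there has been measured. Against that size, only a small rise within the scatter is expected in this assay for this change. The estimate means an expected 1.4-fold higher number from compound 3 to compound 4 (0.15 log units; within the scatter) on this read-out. Compound 4 is estimated at 4500 nM with an expected range from 2500 nM to 8000 nM in this series.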

Compound 4, half-maximal inhibitory concentration: 7240 nM
Compound 4: the middle estimate sits 1.6-fold (0.21 log units) below what was measured, and the stated range covers the measured number.
By their numbers in this assay, from the lowest: compounds 3, 1, 4 and 2 (each within the scatter of the next, the first and the last beyond it).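

At this place on the aromatic ring, chloro now stands apart from methyl as well as from methoxy in this assay (a 2.3-fold higher number from compound 3 to compound 4 (0.36 log units; beyond the scatter)), whereas methyl and methoxy are not separated (a 1.0-fold lower number from compound 2 to compound 4 (0.01 log units; within the scatter)). With methyl on the ring, 4-methylpiperazin-1-yl and hydroxy are not separated either (a 1.3-fold higher number from compound 1 to compound 4 (0.11 log units; within the scatter)). No measured evidence accounts for the chloro result. From the compounds shown here alone, whether fluoro, trifluoromethyl or an amine at this place would read like chloro or like methyl stays open, as does whether the chloro step holds with hydroxy in place of 4-methylpiperazin-1-yl.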